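This account rests on a few compounds, and the source may have more. Where it says the series, first, only, none or still open, it means among the compounds named here.

Of the compounds shown here, three built on a shared core have been measured in a functional assay on A549 cells (Homo sapiens) for inhibition, read by MTT assay, with a stated time of 72 h; a higher number here means a weaker inhibitor of growth, a lower number a stronger inhibitor of growth. Compound 1 `Cc1onc(-c2c(F)cccc2Cl)c1C(=O)Nc1c(-c2ccccc2)[nH]c2ccccc12` gives 9000 nM. Compound 2 `O=C(COc1ccc(Cl)cc1)Nc1c(-c2ccccc2)[nH]c2ccccc12` gives 37000 nM, and compound 3 `CCOC(=O)C1CCN(C(=S)Sc2c(-c3ccc(Br)cc3)[nH]c3ccc(C)cc23)CC1` gives 37000 nM. Compound 3 and compound 2 stand level at the digits shown, together the highest of the three numbers, while compound 1 lies lower by a gap beyond the scatter. Compound 4 `CCOC(=O)C1CCN(C(=S)Sc2c(-c3ccc(Br)cc3)[nH]c3ccc(Cl)cc23)CC1` differs from compound 3 by one change: chloro in place of methyl on an aromatic carbon. For the measured compounds named here, no step between measured compounds that differ in one place is available, so this change has no direct precedent in this assay. The author expects no step beyond the scatter in this assay, the estimated change being no change at the digits printed from compound 3 to compound 4 (within the scatter). Compound 4 is estimated at 37000 nM, with a range from 15000 nM to 90000 nM.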

Compound 4, concentration for 50% growth inhibition: 34000 nM
Beside the measured number, compound 4's estimate is 1.1-fold (0.04 log units) above it; the measured number falls inside the stated range.
By their numbers in this assay, from the lowest: compound 1; then compounds 4, 2 and 3 (each within the scatter of the next).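

In this assay, for the compounds shown here, the swap of methyl for chloro on the six-membered aromatic ring of carbon only gives a 1.1-fold lower number from compound 3 to compound 4 (0.04 log units; within the scatter), the first step between compounds that differ in one place. This place therefore carries either group without a step beyond the scatter, at least with the rest of compound 3 unchanged. Nothing measured here explains this result.

On these data alone, whether an amine or a methoxy group at this place would shift the number remains open. So does whether chloro in place of methyl would give the same small step on another core.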